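This account rests on a few compounds, and the source may have more. Where it says the series, first, only, none or still open, it means among the compounds named here.

Measured so far in a physicochemical assay for solubility, read by LC-MS, in phosphate buffer, with a stated time of 24 h, at pH 7.4; on this read-out lower numbers stand for lower solubility and higher numbers for higher solubility:
- compound 1 `CC1(C)CC(=O)N(c2cnc(NCc3c(F)ccc4c3CCO4)n3cnnc23)C1` gives 57000 nM
- compound 2 `O=C(Nc1cnc(NCc2c(F)ccc3c2CCO3)n2cnnc12)c1ccccc1` gives 2000 nM

Among the compounds with values here, compound 2 holds the lowest of the two numbers, and compound 1 is its only measured neighbour. Still unmeasured is compound 3 `O=C1CCCN1c1cnc(NCc2c(F)ccc3c2CCO3)n2cnnc12`, reached from compound 2 by 2-oxopyrrolidin-1-yl in place of benzamido on an aromatic carbon, in words 2-oxopyrrolidin-1-yl in place of benzamido on an aromatic carbon. Within the data shown here, one measured step bears on this change: a 29-fold lower number from compound 1 to compound 2 (1.45 log units; beyond the scatter), large and beyond the scatter, with benzamido in place of 4,4-dimethyl-2-oxopyrrolidin-1-yl on an aromatic carbon. The change to compound 3 runs that swap backwards, except that the 4,4-dimethyl is absent, and no measurement isolates the 4,4-dimethyl. A large step to a higher number is therefore expected in this assay, estimated as a 23-fold higher number from compound 2 to compound 3 (1.35 log units; beyond the scatter). For compound 3 the estimated value is 45000 nM, with an expected range from 12000 nM to 150000 nM.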

Compound 3, solubility: 640000 nM
For compound 3 the middle estimate is 14-fold (1.15 log units) below the measured one; measured number above the stated range.
By their numbers in this assay, from the lowest: compound 2; then compound 1; then compound 3.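

In this assay the 4,4-dimethyl now has a measured step of its own, an 11-fold higher number from compound 1 to compound 3 (1.05 log units; beyond the scatter), so the number at this aromatic carbon responds to a change within the 2-oxopyrrolidin-1-yl group as well as to a change of group. The direct replacement of benzamido gives a 320-fold higher number from compound 2 to compound 3 (2.51 log units; beyond the scatter), which leaves compound 3 with the highest of the three numbers, its steps to both other compounds being beyond the scatter. No measurement on hand gives a cause for either step.

The compounds shown cannot separate the loss of the hydrogen-bond donor from the loss of the six-membered aromatic ring of carbon only when benzamido leaves. As far as these compounds go, how a primary amine or a carboxylic acid on this aromatic carbon would read also remains open, as does whether a single methyl group matches the 4,4-dimethyl step.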